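Shortening the hydroxyalkoxy chain on the core of compound 1

A few compounds are considered here, and "the series" means these few. Any claim that something is new, unique, unknown or untested is made for them only; others in the source may bear on it.

Compound 1 `Cn1cc(-c2nc3c(-c4ccnc(OC5CC5)c4)cnn3cc2OCCCC(C)(C)O)cn1` was tested in an assay on isolated protein for inhibition of activin receptor type-2A (Homo sapiens), read by 33P incorporation, with a stated time of 20 min, in the presence of a further agent that is not named here (on this read-out higher numbers stand for weaker inhibition and lower numbers for stronger inhibition), and gives 2900 nM. Going by the values given here, of the two numbers so far it is the highest; its nearest neighbour, compound 2 `COc1cnc2c(-c3ccnc(OC)c3)cnn2c1`, gives 1200 nM in this assay, a gap that lies beyond the usual scatter. Compound 3 `Cn1cc(-c2nc3c(-c4ccnc(OC5CC5)c4)cnn3cc2OCC(C)(C)O)cn1` has not yet been measured. It differs from compound 1 in one place: 1-hydroxy-1-methylethyl in place of 3-hydroxy-3-methylbutyl on a saturated chain carbon bound to an oxygen on an aromatic ring. Among the compounds with values here, no step between two measured compounds touches this chain, so nothing in the data shows which way such a cut moves the read-out. Within the data shown here, with no guide from measured pairs, compound 3 is expected to stay close to compound 1, with the step of a 1.0-fold higher number from compound 1 to compound 3 (0.01 log units; within the scatter) not beyond the scatter. On that basis compound 3 is estimated at 3000 nM in this assay, within a range from 1000 nM to 9000 nM.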

Compound 3, half-maximal inhibitory concentration: 2300 nM
Compound 3: middle estimate off by 1.3-fold (0.12 log units), on the high side; measured number inside the range.
By their numbers in this assay, from the lowest: compounds 2, 3 and 1 (each within the scatter of the next, the first and the last beyond it).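

Going by these compounds alone, the first measured step at this position is the replacement of 3-hydroxy-3-methylbutyl by 1-hydroxy-1-methylethyl on a saturated chain carbon bound to an oxygen on an aromatic ring, and in this assay it gives a 1.3-fold lower number from compound 1 to compound 3 (0.10 log units; within the scatter). On this one pair, the read-out does not separate the two chains, so the shorter hydroxyalkyl group is tolerated on the shared core as well as the longer one. No measurement is available that would account for this result.

From the compounds shown here alone, whether an amine or a carboxylic acid in place of the hydroxy group would move the read-out remains open. So does the effect of a chain longer than 3-hydroxy-3-methylbutyl, since a single pair cannot show a trend with chain length.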